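The compounds below may be only part of what the source reports. "The series", "measured", "known", "first", "only" and "open" are said of these compounds alone.

In a functional assay on MDA-MB-231 cells (Homo sapiens) for antiproliferative activity, with a stated time of 48 h (on this read-out lower numbers stand for stronger inhibition and higher numbers for weaker inhibition), compound 1 (`COC(=O)c1cccc(-c2ccc(-n3cccc3)nn2)c1`) gives > 25000 nM as its result, which is a limit of the assay and not a number. Compound 2 (`CCN(CC)c1ccc(-c2cccc(Cl)c2)nn1`) gives > 25000 nM as its result, and this too is a limit. Compound 3 (`CCN(CC)c1ccc(-c2ccc(C#N)cc2)nn1`) stands in the same place, with > 25000 nM as its limit and no number to compare. For the measured compounds named here, all that has been measured so far is the limit of > 25000 nM in this assay, at which 3 of the 3 values shown sit, and nothing more, so no compound here can be ranked against another.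

Compound 4 (`CCN(CC)c1ccc(-c2ccc(C(=O)OC)cc2)nn1`) keeps the rest of compound 3 and changes one group: methoxycarbonyl in place of cyano on an aromatic carbon, para to a large group (methoxycarbonyl in place of cyano on an aromatic carbon) and on a six-membered aromatic ring of carbon only. Going by the values given here, no measured pair shows what a single change of group does in this assay so the expectation has little to lean on. It rests on compound 3, whose result of > 25000 nM is a limit. The expected step of a number no higher from compound 3 to compound 4 (the limit leaves the size open) is an estimate, and it is not expected to go beyond the usual scatter in either direction. For compound 4 the estimate is 25000 nM with an expected range from 10000 nM to 50000 nM and a result that may well be a limit again.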

Compound 4, half-maximal inhibitory concentration: 140 nM
Compound 4: the middle estimate sits 180-fold (2.25 log units) above what was measured; the whole stated range lies above it.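

In this assay, methoxycarbonyl in place of cyano on an aromatic carbon, para to a large group, gives an at least 170-fold lower number from compound 3 to compound 4 (2.25 log units; beyond the scatter), so a single group at this place on the six-membered aromatic ring of carbon only can make a large difference on this read-out. For the compounds shown here, compound 4 gives 140 nM, the first real number in this set, which means that further changes at this place can now be measured in either direction, up or down, from a fixed point. Everything else shown offers no such fixed point, and the size of this step stays open at one end, as its starting point is only a limit: the limit of > 25000 nM in this assay, at which 3 of the 4 values shown sit.

The compounds shown leave open which part of the methoxycarbonyl group carries the difference, and a carboxylic acid, a primary amide or a longer ester such as ethoxycarbonyl at the same place would help to separate the carbonyl from the methyl end. They also leave open whether the same group would give a similar result with something other than the diethylamino group elsewhere on the core, for example a morpholine.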